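Pentyl to hydrogen on the shared core: expected loss

The source may report more compounds than this note shows. Statements on the series, on what has been measured and on what is new or still open speak of the compounds shown alone.

Working notes on the series. Compound 1 `CC(C)c1nccc2nn(-c3ccccc3)cc12` gives in a functional assay on K562 cells (Homo sapiens) for inhibition, read by fluorescence, with a stated time of 72 h (a lower number here means a stronger inhibitor of growth, a higher number a weaker inhibitor of growth), only a limit, > 100000 nM, and so no number. Among the measured compounds shown here, compound 2 `CCCCCc1cc2nn(-c3ccccc3)cc2cn1` gives in this assay 2100 nM, the only numeric value in the set; the other entry is the limit of > 100000 nM in this assay, at which 1 of the 2 values shown sits, so compound 2 cannot be ranked against any other measured compound and stands simply as the one that returned a number. Compound 3 `c1ccc(-n2cc3cnccc3n2)cc1` has not been measured in this assay. Its difference from compound 2 is hydrogen in place of pentyl on an aromatic carbon. For the measured compounds named here, no pair of measured compounds differing in one place exists, so the size of such a step is not known from these data. With the pentyl gone and hydrogen in its place, the expectation for compound 3 is a weaker growth inhibitor than compound 2, a step beyond the scatter rather than a gain or no change. Compound 3 is estimated at 20000 nM in this assay, with a range from 5000 nM to 100000 nM. The expected step is a 9.5-fold higher number from compound 2 to compound 3 (0.98 log units; beyond the scatter); a limit rather than a number is also possible for compound 3.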

Compound 3, concentration for 50% growth inhibition: > 100000 nM
Compound 3: a limit, no number (the forecaster's own chance of this, stated with the estimate: 30%); at least 5.0-fold (0.69 log units) between middle value and limit.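

Hydrogen in place of pentyl on an aromatic carbon, next to the ring nitrogen, gives an at least 47-fold higher number from compound 2 to compound 3 (1.67 log units; beyond the scatter) in this assay, the first readable step in the series and a large one. The value of compound 3, > 100000 nM, is a limit and not a number, so among the compounds shown, only the one carrying pentyl at this position returns a number, and removing that chain takes the series out of the measurable range. The step between compound 1 and compound 3 cannot be read, and the pentyl position gains no second comparison from it: the limit of > 100000 nM in this assay, at which 2 of the 3 values shown sit.

As far as these compounds go, how much of the pentyl chain is needed remains open: a propyl or a longer chain such as heptyl on the same aromatic carbon would give the step a length dependence, and an amine or a carboxylic acid there would test whether a carbon chain is needed at all. Also open, from the compounds shown here alone, is whether isopropyl, set on the carbon that holds the pentyl in compound 2, would return a number in this assay.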